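From Hexyloxy to Fluoro on a Shared Core

A few compounds are considered here, and "the series" means these few. Any claim that something is new, unique, unknown or untested is made for them only; others in the source may bear on it.

Three close relatives sharing one core have been tested in a functional assay on B16-F10 cells (Mus musculus) for antiproliferative activity, read by MTT assay, with a stated time of 48 h; on this read-out lower numbers stand for stronger inhibition and higher numbers for weaker inhibition. There compound 1 `CCCC(C)Oc1ccc(C(=O)/C=C/c2c(/C=C/c3ccc(OC)cc3)cc(OC)cc2OC)cc1` gives 6.7 ug/mL, compound 2 `COc1ccc(/C=C/c2cc(OC)cc(OC)c2/C=C/C(=O)c2ccc(C)cc2)cc1` gives 5.3 ug/mL, and compound 3 `CCCCCCOc1ccc(C(=O)/C=C/c2c(/C=C/c3ccc(OC)cc3)cc(OC)cc2OC)cc1` gives 10.4 ug/mL. Compound 3 therefore stands within the usual scatter of both others, as a 1.6-fold higher number from compound 1 to compound 3 (0.19 log units; within the scatter) and a 2.0-fold higher number from compound 2 to compound 3 (0.29 log units; within the scatter) show.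

The unmeasured compound 4 `COc1ccc(/C=C/c2cc(OC)cc(OC)c2/C=C/C(=O)c2ccc(F)cc2)cc1` carries fluoro in place of hexyloxy on an aromatic carbon. For the measured compounds named here, no measured compound carries fluoro, so the evidence is indirect. The closest guide is the change of the group in this same place, seen in a 2.0-fold higher number from compound 2 to compound 3 (0.29 log units; within the scatter) and a 1.3-fold lower number from compound 1 to compound 2 (0.10 log units; within the scatter). Both steps stay within the scatter, so a large change is not expected here. The expected step is a 1.7-fold lower number from compound 3 to compound 4 (0.24 log units; within the scatter), which would be no real change beyond the scatter. For compound 4 the estimated value is 6 ug/mL, with an expected range from 3 ug/mL to 12 ug/mL.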

Compound 4, half-maximal inhibitory concentration: 5.3 ug/mL
Compound 4: the middle estimate sits 1.1-fold (0.05 log units) above what was measured; the range from low to high includes it.
By their numbers in this assay, from the lowest: compounds 2, 4, 1 and 3 (each within the scatter of the next).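

Fluoro is a far smaller group than any chain tested at this place, para to a large group, yet in this assay the steps remain small: a 2.0-fold lower number from compound 3 to compound 4 (0.29 log units; within the scatter), a 1.3-fold lower number from compound 1 to compound 4 (0.10 log units; within the scatter) and no change at the digits printed from compound 2 to compound 4 (within the scatter). Across a single fluorine atom, methyl and the two oxygen-linked chains, hexyloxy and 1-methylbutoxy, no step at this place has moved beyond the scatter, so this read-out does not tell these groups apart. Nothing available here explains this lack of separation.

From the compounds shown here alone, whether a group of another kind at this place, such as an amine or a carboxylic acid, would give a step beyond the scatter stays open. So does the outcome with a chain longer than hexyloxy.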